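This account rests on a few compounds, and the source may have more. Where it says the series, first, only, none or still open, it means among the compounds named here.

Series notes. Compound 1 `CCS(=O)(=O)Nc1ccc(CNC(=O)c2ccc(C(C)(C)C)cc2)c(Cl)c1`, compound 2 `CC(C)(C)c1ccc(C(=O)NCc2c(Cl)cc(NS(C)(=O)=O)cc2Cl)cc1` and compound 3 `CS(=O)(=O)Nc1ccc(CNC(=O)c2ccc(C34CC(C3)C4)cc2)c(Cl)c1` have each been run in an ADME assay on microsomes from liver (Rattus norvegicus, strain Sprague-Dawley) for metabolic stability, read by HPLC, using NADPH, with stated times of 5 min and 60 min, tested at 10 uM; on this read-out higher numbers stand for fast clearance and lower numbers for slow clearance. Compound 1 gives 28 mL.min-1.g-1, compound 2 gives 16 mL.min-1.g-1 and compound 3 gives 17 mL.min-1.g-1. On these three numbers compound 3 is the second highest, but its gaps to compound 2 and to compound 1 both fall within the scatter, so no real order among the three can be read. Compound 4 `CC(C)Oc1ccc(C(=O)NCc2ccc(NS(C)(=O)=O)cc2Cl)cc1` has not yet been measured in this assay. Its change from compound 3 is a group of 4 heavy atoms (3 carbon, 1 oxygen; no ring) in place of a group of 5 heavy atoms (5 carbon; 2 four-membered non-aromatic rings of carbon only), on an aromatic carbon. Going by the values given here, no measured pair shows this change, so in this assay the step expected is a 1.5-fold higher number from compound 3 to compound 4 (0.17 log units; within the scatter), upward but not beyond the scatter. Compound 4 is expected to give 25 mL.min-1.g-1, with a range from 10 mL.min-1.g-1 to 60 mL.min-1.g-1.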

Compound 4, intrinsic clearance in microsomes: 12 mL.min-1.g-1
Compound 4: the middle estimate sits 2.1-fold (0.32 log units) above what was measured; low and high end bracket the measured number.
By their numbers in this assay, from the lowest: compounds 4, 2, 3 and 1 (each within the scatter of the next, the first and the last beyond it).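

In this assay, the aromatic carbon para to a large group takes isopropoxy in place of the group with two four-membered carbon rings, giving a 1.4-fold lower number from compound 3 to compound 4 (0.15 log units; within the scatter). Going by these compounds alone, this is the first step that can be read at this position, and it shows that an oxygen-linked group without a ring can stand there with no change beyond the scatter. Nothing on hand speaks to a cause for this step. Still open, from the compounds shown here alone, is whether a carboxylic acid or a dimethylamino group on this carbon would stay within the scatter of compound 3. Also open, going by these compounds, is whether isopropoxy would give a similar step on the core of compound 2.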